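Ethyl to Isopropyl on the Aryl Urea Core

The source may hold more compounds than are shown below. What is called first, only, known or untested is meant among the compounds shown, and "the series" means these compounds.

Measured compounds:
compound 1 `CCc1cccc(NC(=O)N[C@H](C)c2ccccc2)c1` with 71%
compound 2 `CCc1cccc(NC(=O)N[C@@H](C)c2ccccc2)c1` with 94%

In an ADME assay on the whole organism with Oryza sativa as the target, tested at 1 uM (on this read-out lower numbers stand for a stronger effect and higher numbers for a weaker effect at the one concentration tested), compound 2 stands highest of the two numbers measured, and its nearest neighbour is compound 1 with a number 23 percentage points higher from compound 1 to compound 2 (beyond the scatter). These two compounds share every atom and bond and differ only in the configuration as drawn (the fact that compounds 1 and 2 differ only in the configuration as drawn).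

Compound 3 `CC(C)c1cccc(NC(=O)N[C@@H](C)c2ccccc2)c1` is not yet measured. It differs from compound 2 by methyl in place of hydrogen on a saturated chain carbon bound to an aromatic carbon and a saturated chain carbon. Cut one bond further out, the same difference reads ethyl to isopropyl.

Within the data shown here, none of the measured steps bears on this change: the only step known, from compound 1 to compound 2, concerns a stereocentre alone and says nothing about growth on the ethyl group. With no guide from the data, the expected step in this assay is none beyond the scatter, so the step of a number 4 percentage points lower from compound 2 to compound 3 (within the scatter) is an estimate set close to zero. Compound 3 is therefore estimated at 90%, with a range from 70% to 100%.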

Compound 3, a percentage reported as activity, at one concentration (the size of the read-out at that concentration, not a potency): 84%
Compound 3: middle estimate off by 6 percentage points, on the high side; the measured number falls inside the stated range.
By their numbers in this assay, from the lowest: compound 1; then compounds 3 and 2 (each within the scatter of the next).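

In this assay, this first look at growth on the ethyl group gives a number 10 percentage points lower from compound 2 to compound 3 (within the scatter), so methyl in place of hydrogen on this saturated chain carbon does not set compound 3 apart from compound 2. With the configuration drawn in compound 2, the carbon bound to an aromatic carbon and a saturated chain carbon therefore takes the change from ethyl to isopropyl without a difference that can be told from the scatter. The earlier pair spoke only to the stereocentre, and nothing at hand bears on the reason for this outcome.

The compounds shown leave open whether the isopropyl group would read the same with the configuration drawn in compound 1, as the only pair that differs at the stereocentre carries ethyl. They also leave open how a tert-butyl group, a cyclopropyl ring or a methoxy group at this place would read in this assay, and so how far the tolerance seen for this single added methyl extends.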